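Methoxy for Methyl on a Macrolide Aryl Ether

The source may report more compounds than this note shows. Statements on the series, on what has been measured and on what is new or still open speak of the compounds shown alone.

Compound 1, `CC[C@@H]1/C=C(\C)C[C@H](C)C[C@H](OC)[C@H]2O[C@@](O)(C(=O)C(=O)N3CCCC[C@H]3C(=O)O[C@H](/C(C)=C/[C@@H]3CC[C@@H](O)[C@H](Oc4ccc(C)cc4)C3)[C@H](C)[C@@H](O)CC1=O)[C@H](C)C[C@@H]2OC`, in a functional assay on cells for inhibition, with Murine T-cell line (Mus musculus) as the target; a higher number here means a weaker inhibitor, a lower number a stronger inhibitor: 2.6 nM
Compound 2, `CC[C@@H]1/C=C(\C)C[C@H](C)C[C@H](OC)[C@H]2O[C@@](O)(C(=O)C(=O)N3CCCC[C@H]3C(=O)O[C@H](/C(C)=C/[C@@H]3CC[C@@H](O)[C@H](Oc4ccc(OC)cc4)C3)[C@H](C)[C@@H](O)CC1=O)[C@H](C)C[C@@H]2OC`, in this assay: 0.9 nM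
Compound 3, `CC[C@@H]1/C=C(\C)C[C@H](C)C[C@H](OC)[C@H]2O[C@@](O)(C(=O)C(=O)N3CCCC[C@H]3C(=O)O[C@H](/C(C)=C/[C@@H]3CC[C@@H](Oc4ccc(C)cc4)[C@H](O)C3)[C@H](C)[C@@H](O)CC1=O)[C@H](C)C[C@@H]2OC`, in this assay: 6 nM

Compound 1 and compound 2 share a core and differ only by methoxy in place of methyl on an aromatic carbon. That change gave a 2.9-fold lower number from compound 1 to compound 2 (0.46 log units; beyond the scatter). Compound 3 has the same atoms as compound 1 joined differently; the difference between the two cores is not broken down here. In this assay compound 3 gives the highest of the three numbers.

Compound 4, `CC[C@@H]1/C=C(\C)C[C@H](C)C[C@H](OC)[C@H]2O[C@@](O)(C(=O)C(=O)N3CCCC[C@H]3C(=O)O[C@H](/C(C)=C/[C@@H]3CC[C@@H](Oc4ccc(OC)cc4)[C@H](O)C3)[C@H](C)[C@@H](O)CC1=O)[C@H](C)C[C@@H]2OC`, is not yet measured. It differs from compound 3 by methoxy in place of methyl on an aromatic carbon, and the place described for it is the same, word for word, as the place described for the change from compound 1 to compound 2, so it is the same change on a different core. Within the data shown here, only one earlier instance exists, so the expectation rests on it alone. Compound 4 is expected to show a step of a 2.9-fold lower number from compound 3 to compound 4 (0.46 log units; beyond the scatter), estimated because the earlier step was a 2.9-fold lower number from compound 1 to compound 2 (0.46 log units; beyond the scatter). Compound 4 is thus estimated at 2.1 nM, between 0.8 nM and 6 nM.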

Compound 4, half-maximal inhibitory concentration: 1.2 nM
For compound 4 the middle estimate is 1.8-fold (0.24 log units) above the measured one; low and high end bracket the measured number.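

Replacing methyl with methoxy on the aromatic ring lowered the number on the second core as it did on the first, and the new step in this assay is a 5.0-fold lower number from compound 3 to compound 4 (0.70 log units; beyond the scatter). The two steps do not differ in size beyond what repeated measurements would allow: the same change on two cores in this assay, a 2.9-fold lower number (0.46 log units; beyond the scatter) from compound 1 to compound 2 and a 5.0-fold lower number (0.70 log units; beyond the scatter) from compound 3 to compound 4, 1.7-fold (0.24 log units) apart, within the scatter of two such steps

So, between these two cores, the change carried over in both direction and size, but with only two pairs this does not show that it would hold on any other core in the series, nor does it explain why methoxy gives the lower number.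

The compounds shown carry only methyl or methoxy at this place, which leaves open how an ethoxy group, a longer chain, a hydroxyl or an amine would behave there. They also leave open whether the methoxy step would look the same on a core that differs more from these two than they differ from each other.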